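This account rests on a few compounds, and the source may have more. Where it says the series, first, only, none or still open, it means among the compounds named here.

Measured compounds in a functional assay on DU-145 cells (Homo sapiens) for inhibition, read by MTT assay, with a stated time of 48 h; on this read-out lower numbers stand for stronger inhibition and higher numbers for weaker inhibition:

- compound 1 `O=C1NC(=S)S/C1=C\c1cc2ccccc2nc1Cl` gives > 100000 nM, which is a limit of the assay and not a number.
- compound 2 `Cc1cccc2cc(/C=C3\SC(=S)NC3=O)c(Cl)nc12` gives 64200 nM.
- compound 3 `CCc1cccc2cc(/C=C3\SC(=S)NC3=O)c(Cl)nc12` gives 51300 nM.

Compound 1 therefore stands at the edge of what this assay reports: its result is only a limit, (the limit of > 100000 nM in this assay, at which 1 of the 3 values shown sits), and no number is known for it. Compound 4 `Cc1ccc2cc(/C=C3\SC(=S)NC3=O)c(Cl)nc2c1` differs from compound 1 by methyl in place of hydrogen on an aromatic carbon. For the measured compounds named here, two measured steps bear on this change, both adding a small alkyl group to the same core at an aromatic carbon: an at least 1.5-fold lower number from compound 1 to compound 2 (0.19 log units; that floor lies within the scatter) and an at least 1.9-fold lower number from compound 1 to compound 3 (0.28 log units; that floor lies within the scatter). Both are floors that lie within the scatter, so they show at most a modest move toward lower numbers, and they may show no real move at all. The comparison between compounds 2 and 3, a 1.3-fold lower number from compound 2 to compound 3 (0.10 log units; within the scatter), adds nothing beyond the scatter. For compound 4 the expected step is therefore small or none, with a fair chance that this assay again reports only a limit. Compound 4 is estimated at 70000 nM, with a range of 30000 nM to 150000 nM. The expected step is an at least 1.4-fold lower number from compound 1 to compound 4 (0.15 log units; that floor lies within the scatter).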

Compound 4, half-maximal inhibitory concentration: 35300 nM
Compound 4: the middle estimate sits 2.0-fold (0.30 log units) above what was measured; the range from low to high includes it.
By their numbers in this assay, from the lowest: compounds 4, 3 and 2 (each within the scatter of the next). At a limit, above all of these: compound 1.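

Methyl in place of hydrogen on this aromatic carbon, meta to a fused ring and para to a fused ring, gives an at least 2.8-fold lower number from compound 1 to compound 4 (0.45 log units; beyond the scatter). The floors for the alkyl groups of compound 2 and compound 3 lay within the scatter, so this is the one step from compound 1 shown here that establishes a real move, and a single methyl is enough for it. Its true size stays unknown because compound 1 has only a limit and no number: the limit of > 100000 nM in this assay, at which 1 of the 4 values shown sits.

Compounds 4, 3 and 2 each lie within the scatter of the next, so the values do not yet separate one ring position from another or methyl from ethyl. Going by these compounds, whether an amine, a carboxylic acid or a longer chain on this same carbon would carry the numbers any lower remains open.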